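This account rests on a few compounds, and the source may have more. Where it says the series, first, only, none or still open, it means among the compounds named here.

Measured compounds:
- compound 2, `COC(=O)c1ccc(NCc2cncn2Cc2ccc(C)cc2)cc1-c1ccccc1`, gives 50000 nM
- compound 3, `COC(=O)c1ccc(NCc2cncn2Cc2ccc(Cl)cc2)cc1-c1ccccc1`, gives 25000 nM
- compound 1, `COC(=O)c1ccc(NCc2cncn2Cc2ccccc2C(C)(C)C)cc1-c1ccccc1`, gives "not determined" (no result reported), so no number was obtained for it

The read-out here is a toxicity assay on NIH3T3 cells (Mus musculus) for cytotoxicity, read by resazurin assay; a lower number here means that less compound is needed, a higher number that more compound is needed for the effect. For the measured compounds named here, compound 3 has the lowest of the two numbers known, but its only neighbour is compound 2, and the step of a 2.0-fold lower number from compound 2 to compound 3 (0.30 log units; within the scatter) lies within the scatter, so the two compounds cannot be told apart on this measure. Compound 1 adds nothing, as no number was obtained for it.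

The next compound is compound 4, `COC(=O)c1ccc(NCc2cncn2Cc2ccc(-c3ccccc3)cc2)cc1-c1ccccc1`. It differs from compound 3 in one place: phenyl in place of chloro on an aromatic carbon. The change sits para to a large group on the shared core.

Going by the values given here, no measured step covers this exchange. Among the compounds with values here, the one step that exists, from compound 2 to compound 3, swaps one small group for another and stays within the scatter. Within the data shown here, a phenyl ring is a larger replacement than a chloro, so the data give no direct guide, only the observation that the one change tried at this position moved the number little. The expectation is therefore a step of no change at the digits printed from compound 3 to compound 4 (within the scatter), no clear direction, with a wide range. Compound 4 is estimated at 25000 nM, between 8000 nM and 80000 nM.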

Compound 4, half-maximal effective concentration: > 1000 nM
Compound 4: a limit, no number (the forecaster's own chance of this, stated with the estimate: 20%); the middle value is on the limit's open side.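

In this assay compound 4 gives > 1000 nM, which is a limit of the assay and not a number. The steps from compound 2 and from compound 3 to compound 4 therefore cannot be read. The compounds shown leave open whether phenyl in place of methyl or chloro changes the number at all, and in which direction.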